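Cytotoxicity notes: removing the hydroxy from compound 3

A few compounds are considered here, and "the series" means these few. Any claim that something is new, unique, unknown or untested is made for them only; others in the source may bear on it.

Three measured compounds share one core: compound 1 `COc1ccc2[nH]c(-c3ccc[se]3)cc(=O)c2c1`, compound 2 `COc1ccc2[nH]c(-c3ccc(C)[se]3)cc(=O)c2c1OC` and compound 3 `COc1ccc2[nH]c(-c3ccc(C)[se]3)cc(=O)c2c1O`. In an ADME assay on Detroit 551 cells (Homo sapiens) for cytotoxicity, read by MTT assay, with a stated time of 48 h (on this read-out lower numbers stand for stronger inhibition and higher numbers for weaker inhibition), compound 1 gives > 10000 nM, which is a limit of the assay rather than a number. In this assay compound 2 gives > 50000 nM, likewise a limit. In this assay compound 3 gives > 50000 nM, again a limit. Compound 3 therefore stands only at a limit; the limit of > 10000 nM in this assay, at which 1 of the 3 values shown sits, and the limit of > 50000 nM in this assay, at which 2 of the 3 values shown sit, cover everything that is known of the three. The single-place step that the two limits leave unreadable from compound 2 to compound 3 cannot be sized.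

Compound 4 `COc1ccc2[nH]c(-c3ccc(C)[se]3)cc(=O)c2c1` differs from compound 3 by hydrogen in place of hydroxy on an aromatic carbon. For the measured compounds named here, no measured step bears directly on this change, and the only comparable one-place step, a step that the two limits leave unreadable from compound 2 to compound 3, is unreadable. Nothing in the three values points to any size or direction of step in this assay, and no step beyond the scatter is expected. Compound 4 is expected to give 60000 nM in this assay, within 15000 nM to 200000 nM, and most probably again reported only as a limit. The expected step that the limit leaves unreadable from compound 3 to compound 4 is estimated as essentially flat.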

Compound 4, half-maximal inhibitory concentration: > 10000 nM
Compound 4 ended at the assay's limit; the forecaster's own chance of this, stated with the estimate: 85%; the middle value lies beyond the limit too.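

Compound 4 adds only a limit, and its steps from compound 1, compound 2 and compound 3 in this assay cannot be read. The compounds shown leave open whether any of the four has a measurable cytotoxic potency in this assay, and whether the methyl, hydroxy or methoxy changes alter it.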